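Adding a methoxy to the ethyl arm of compound 1

The source may hold more compounds than are shown below. What is called first, only, known or untested is meant among the compounds shown, and "the series" means these compounds.

Compound 1 `CCN(Cc1cccs1)C(=O)COc1ccc(C)cc1`: 8 nM
Compound 2 `CCN(Cc1c[nH]nn1)C(=O)COc1ccc(C)cc1`: 31100 nM
Compound 3 `CCN(Cc1cccs1)C(=O)C(C)Oc1ccc(C)cc1`: 889 nM

In an assay on HEK293 cells for agonist activity at transient receptor potential cation channel subfamily M member 8 (Homo sapiens), read by fluorescence and calcium flux, with a stated time of 15 min (on this read-out lower numbers stand for an effect already at smaller amounts and higher numbers for an effect only at larger amounts of compound), compound 1 gives 8 nM, the lowest of the three numbers. Compound 2 lies furthest from it with 31100 nM, a change of a 3900-fold higher number from compound 1 to compound 2 (3.59 log units; beyond the scatter). Compound 3 comes nearer with 889 nM, a change of a 110-fold higher number from compound 1 to compound 3 (2.05 log units; beyond the scatter). Both steps beyond the scatter are large rises, and each touches a different part of the shared core.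

Compound 4 `COCCN(Cc1cccs1)C(=O)COc1ccc(C)cc1` differs from compound 1 by methoxy in place of hydrogen on a saturated chain carbon, two bonds along the chain from an amide-type nitrogen; cut one bond further out, the change reads ethyl to 2-methoxyethyl. Within the data shown here, neither measured step touches this arm, so no step bears on it directly; they only show that the shared core has so far given large rises upon change. A small to moderate rise in this assay is therefore expected, and the step is estimated at a 3.8-fold higher number from compound 1 to compound 4 (0.57 log units; beyond the scatter). Compound 4 is expected to give 30 nM, within a range of 8 nM to 200 nM.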

Compound 4, half-maximal effective concentration: 400 nM
Beside the measured number, compound 4's estimate is 13-fold (1.12 log units) below it, and the stated range ends below it.
By their numbers in this assay, from the lowest: compound 1; then compound 4; then compound 3; then compound 2.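

Among these compounds, the ethyl arm of compound 1, which no earlier step touched, also proves sensitive: in this assay, methoxy in place of hydrogen on a saturated chain carbon, two bonds along the chain from an amide-type nitrogen, gives a 50-fold higher number from compound 1 to compound 4 (1.70 log units; beyond the scatter). With this result, all three single changes shown for compound 1 give large rises, and no compound shown goes against that, so the low number of compound 1 has now been lost at three different places. Nothing available explains the size of this rise.

A single compound cannot separate the effect of the added oxygen from that of the longer arm, so a plain propyl or butyl chain in place of ethyl remains an open comparison. From the compounds shown here alone, it is also open how a methyl in place of ethyl, or a 2-hydroxyethyl or 2-aminoethyl arm, would read out here.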